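Compound 3 to compound 4: a group exchange at the limit

The compounds below may be only part of what the source reports. "The series", "measured", "known", "first", "only" and "open" are said of these compounds alone.

In a physicochemical assay for solubility, in phosphate buffer, measured as thermodynamic solubility, at pH 7.4 (a higher number here means a more soluble compound, a lower number a less soluble compound), compound 3 `CN(C(=O)CCc1cn(-c2ccc(Br)cc2)nc1-c1ccc(Cl)cc1)S(C)(=O)=O` stands at < 5000 nM as a limit and not as a number. Compound 2 `CNC(=O)CCc1cn(-c2ccc(Br)cc2)nc1-c1ccc(Cl)cc1` gives < 5000 nM as a limit too. Compound 1 `CS(=O)(=O)NC(=O)CCc1cn(-c2cccc(Br)c2)nc1-c1ccc(Cl)cc1` gives < 5000 nM as a limit too. The whole record is the limit of < 5000 nM in this assay, at which 3 of the 3 values shown sit, and the series holds no actual number yet. Among the compounds with values here, the one measured step is a step that the two limits leave unreadable from compound 2 to compound 3 and no size can be carried over from it.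

Compound 4 `CC(=O)NS(=O)(=O)CCc1cn(-c2ccc(Br)cc2)nc1-c1ccc(Cl)cc1` differs by acetylsulfamoyl in place of methyl(methylsulfonyl)carbamoyl on a saturated chain carbon, two bonds along the chain from an aromatic carbon with acetylsulfamoyl in place of methyl(methylsulfonyl)carbamoyl on a saturated chain carbon, two bonds along the chain from an aromatic carbon.

In this assay the expected change is a step that the limit leaves unreadable from compound 3 to compound 4 and no step beyond the scatter is expected, in either direction. Compound 4 is expected to be reported as a limit as well, given that compound 3 sits at < 5000 nM as a limit. The estimate for compound 4 is 4000 nM with an expected range from 1000 nM to 15000 nM at its ends.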

Compound 4, solubility: 165000 nM
Compound 4: the middle estimate sits 41-fold (1.62 log units) below what was measured, and the stated range ends below it.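

In this assay, compound 4 gives the series its first actual number, showing that the group on this saturated chain carbon, two bonds along the chain from an aromatic carbon, can carry a large step. Acetylsulfamoyl in place of methyl(methylsulfonyl)carbamoyl gives an at least 33-fold higher number from compound 3 to compound 4 (1.51 log units; beyond the scatter), and acetylsulfamoyl in place of methylcarbamoyl gives an at least 33-fold higher number from compound 2 to compound 4 (1.51 log units; beyond the scatter). The other compounds offer no number to set beside it, and the step between them cannot be read: the limit of < 5000 nM in this assay, at which 3 of the 4 values shown sit.

The compounds shown do not separate the contribution of the acetyl group from that of the sulfonyl group attached directly to the chain, or from that of the nitrogen hydrogen. A carboxylic acid or an unsubstituted sulfonamide on the same chain carbon would test those parts, and a longer chain would test how far the step depends on the chain.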